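Formyl for sulfanyl on the shared core

A few compounds are considered here, and "the series" means these few. Any claim that something is new, unique, unknown or untested is made for them only; others in the source may bear on it.

In a functional assay on P388 cells (Mus musculus) for cytotoxicity (a lower number here means a stronger inhibitor, a higher number a weaker inhibitor), compound 1 `COc1ccc(C[C@H]2C(=O)N[C@@H](C)C(=O)N(C)[C@H]3Cc4ccc(cc4)Oc4cc(ccc4OC)C[C@@H](C(=O)N[C@H](C)C(=O)NC4(SCCS4)C(=O)N2C)N(C)C3=O)cc1` gives 631 nM and compound 2 `COc1ccc(C[C@H]2C(=O)N[C@@H](C)C(=O)N(C)[C@H]3Cc4ccc(cc4)Oc4cc(ccc4OC)C[C@@H](C(=O)N[C@H](C)C(=O)N[C@@H](CS)C(=O)N2C)N(C)C3=O)cc1` gives 363 nM, two values within the scatter of each other. For the measured compounds named here, compound 2 therefore stands level with compound 1, the only other measured member of this small set, and neither can be ranked on these numbers.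

The next compound is compound 3 `COc1ccc(C[C@H]2C(=O)N[C@@H](C)C(=O)N(C)[C@H]3Cc4ccc(cc4)Oc4cc(ccc4OC)C[C@@H](C(=O)N[C@H](C)C(=O)N[C@@H](CC=O)C(=O)N2C)N(C)C3=O)cc1`, which departs from compound 2 by a single exchange: formyl in place of sulfanyl on a saturated chain carbon bound to a saturated ring carbon.

Going by the values given here, the data hold no measured pair that differs in one place, so nothing here shows directly what this exchange does in this assay. The expectation rests on compound 2 at 363 nM, with compound 1 at 631 nM as the only other reference. No step beyond the scatter is expected in either direction, and the estimated step is a 1.1-fold higher number from compound 2 to compound 3 (0.04 log units; within the scatter). With so little to go on, the range is kept wide. Compound 3 is expected at 400 nM, with an estimated range of 100 nM to 1500 nM.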

Compound 3, half-maximal inhibitory concentration: 33.9 nM
Beside the measured number, compound 3's estimate is 12-fold (1.07 log units) above it; measured number below the stated range.
By their numbers in this assay, from the lowest: compound 3; then compounds 2 and 1 (each within the scatter of the next).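

In this assay, formyl in place of sulfanyl on a saturated chain carbon bound to a saturated ring carbon gives an 11-fold lower number from compound 2 to compound 3 (1.03 log units; beyond the scatter), which is beyond the scatter and shows that the activity of the series responds to what this position carries, something the earlier values, level with each other, could not show. The exchange brings several differences at once: sulfanyl leaves with its hydrogen-bond donor, while formyl enters with no hydrogen-bond donor, a hydrogen-bond acceptor and a double bond outside aromatic rings, and this single pair cannot separate them. Nothing available bears on why the number falls by this much.

Still open, on these data alone, is whether the step follows from the arrival of formyl or from the departure of sulfanyl, and a hydroxymethyl, a carboxylic acid or an amine at the same place would help to tell these apart. Also open, as far as these compounds go, is whether a longer chain ending in formyl would keep the low number of compound 3, 33.9 nM.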